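The source may hold more compounds than are shown below. What is called first, only, known or untested is meant among the compounds shown, and "the series" means these compounds.

Read-out for the series: a functional assay on the whole organism with Rattus norvegicus as the target, at a dose of 1 mg/kg by the oral route; on this read-out higher numbers stand for a stronger effect at the one dose given and lower numbers for a weaker effect.

Measured so far:
compound 1, `CCc1ccc(-c2cc(OC)cc(C(=O)Nc3nn[nH]n3)n2)cc1`, gives 43%
compound 2, `COc1cc(C(=O)Nc2nn[nH]n2)nc(-c2ccc(C(C)C)cc2)c1`, gives 54%
compound 3, `CCOc1cc(C(=O)Nc2nn[nH]n2)nc(-c2ccc(N)cc2)c1`, gives 52%

Compound 1 and compound 2 differ in one place, (methyl in place of hydrogen on a saturated chain carbon bound to an aromatic carbon and a saturated chain carbon), and the step is a number 11 percentage points higher from compound 1 to compound 2 (beyond the scatter). Compound 3 sits on a different core; how that core differs from the core of compound 1 is not broken down here, and the values of compound 2 and compound 3 lie within the scatter of each other.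

Compound 4, `CCCOc1cc(C(=O)Nc2nn[nH]n2)nc(-c2ccc(N)cc2)c1`, is not yet measured. It differs from compound 3 by methyl in place of hydrogen on a saturated chain carbon, two bonds along the chain from an oxygen on an aromatic ring. This is the same kind of change as from compound 1 to compound 2, but not the same: there the entering methyl sits on a saturated chain carbon bound to an aromatic carbon and a saturated chain carbon, here on a saturated chain carbon, two bonds along the chain from an oxygen on an aromatic ring.

The expected step from compound 3 to compound 4 is a number 6 percentage points higher from compound 3 to compound 4 (within the scatter), resting on the earlier step of a number 11 percentage points higher from compound 1 to compound 2 (beyond the scatter), tempered because the place differs and compound 3 starts from 52%. Compound 4 is therefore estimated at 58%, expected between 42% and 74%.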

Compound 4, a percentage reported as inhibition, in the whole organism at one dose (the size of the read-out at that dose, not a potency): 64%
Beside the measured number, compound 4's estimate is 6 percentage points below it, within the range that was stated.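

Extending ethoxy to propoxy raises the read-out in this assay, a number 12 percentage points higher from compound 3 to compound 4 (beyond the scatter). Methyl in place of hydrogen has now given a gain of matching size in two pairs on different cores, at a different place in each pair: the same change on two cores in this assay, a number 11 percentage points higher (beyond the scatter) from compound 1 to compound 2 and a number 12 percentage points higher (beyond the scatter) from compound 3 to compound 4, 1 percentage points apart, within the scatter of two such steps. This supports carrying the change over between these two cores, but two pairs set no rule for the series, and because the entering methyl sits at a different place in each pair, the match does not separate the influence of the core from that of the place; the read-out also gives the size of the effect at one dose, not a potency.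

The compounds shown leave open whether the gain continues with a longer chain such as butoxy, or holds for a branched chain such as isopropoxy. Also open, from the compounds shown here alone, is whether the step survives on a core in which a carboxylic acid stands in place of the amine of compound 4.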